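This account rests on a few compounds, and the source may have more. Where it says the series, first, only, none or still open, it means among the compounds named here.

In an ADME assay on MRC5 cells (Homo sapiens) for cytotoxicity, read by neutral red uptake (on this read-out lower numbers stand for higher toxicity in this test and higher numbers for lower toxicity in this test), so far:
- compound 1 `O=c1[nH]c(SCc2ccccc2)nc2ccccc12` gives > 64000 nM as a limit
- compound 2 `O=c1[nH]c(SCc2cccs2)nc2ccccc12` gives > 64000 nM as a limit

Among the measured compounds shown here, compound 1 thus stands only at a limit, with no number, and so does the one further compound (the limit of > 64000 nM in this assay, at which 2 of the 2 values shown sit). Compound 3 `COc1cccc(CSc2nc3ccccc3c(=O)[nH]2)c1` has methoxy in place of hydrogen on an aromatic carbon. For the measured compounds named here, the one measured step (a step that the two limits leave unreadable from compound 1 to compound 2) has no readable size, so no step beyond the scatter is expected in this assay for this change. The estimated step (a number no higher from compound 1 to compound 3 (the limit leaves the size open)) reflects that expectation. Compound 3 is estimated at 64000 nM and will probably be reported as a limit again (expected range 20000 nM to 64000 nM).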

Compound 3, half-maximal cytotoxic concentration: > 64000 nM
Compound 3 ended at the assay's limit (the forecaster's own chance of this, stated with the estimate: 70%); the middle value lies on the limit itself.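

No step can be read from compound 1 to compound 3, as both values are limits: the limit of > 64000 nM in this assay, at which 3 of the 3 values shown sit. The compounds shown leave open where any half-maximal cytotoxic concentration lies, and whether methoxy in place of hydrogen on an aromatic carbon changes it.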